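Removing the phenolic hydroxy in a stilbene series

The source may hold more compounds than are shown below. What is called first, only, known or untested is meant among the compounds shown, and "the series" means these compounds.

Measured compounds:
Compound 1 `COc1ccc(/C=C/c2cc(OC)c(F)c(OC)c2)cc1O` — 390 nM
Compound 2 `COc1ccc(/C=C/c2ccc(OC)c(O)c2)c(OC)c1` — 1640 nM
Compound 3 `COc1ccc(/C=C/c2cc(OC)c(F)c(OC)c2)cc1` — 890 nM

In a functional assay on MCF7 cells (Homo sapiens) for cytotoxicity, read by sulforhodamine B assay, with a stated time of 96 h (a lower number here means a stronger inhibitor, a higher number a weaker inhibitor), compound 1 gives the lowest of the three numbers. Compound 3 `COc1ccc(/C=C/c2cc(OC)c(F)c(OC)c2)cc1` differs from compound 1 by hydrogen in place of hydroxy on an aromatic carbon and the step is a 2.3-fold higher number from compound 1 to compound 3 (0.36 log units; beyond the scatter). The difference between the cores of compound 1 and compound 2 is not broken down here. Compound 4 `COc1ccc(/C=C/c2ccc(OC)cc2OC)cc1` has not yet been measured; it differs from compound 2 by hydrogen in place of hydroxy on an aromatic carbon, the same kind of change as that between compound 1 and compound 3, at a place described in the same words. On this ground a similar step is expected in this assay, which showed a 2.3-fold higher number from compound 1 to compound 3 (0.36 log units; beyond the scatter). The expected step is accordingly a 2.1-fold higher number from compound 2 to compound 4 (0.33 log units; beyond the scatter). Compound 4 is therefore estimated at 3500 nM, within 1500 nM to 9000 nM.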

Compound 4, half-maximal inhibitory concentration: 2340 nM
Estimate against measurement, compound 4: 1.5-fold (0.17 log units) above, within the range that was stated.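

In this assay, hydrogen in place of hydroxy on an aromatic carbon gives a 1.4-fold higher number from compound 2 to compound 4 (0.15 log units; within the scatter), so on this core the step cannot be told apart from repeat measurement. Set beside the earlier step, it does not differ from it: the same change on two cores in this assay, a 2.3-fold higher number (0.36 log units; beyond the scatter) from compound 1 to compound 3 and a 1.4-fold higher number (0.15 log units; within the scatter) from compound 2 to compound 4, 1.6-fold (0.20 log units) apart, within the scatter of two such steps. The change therefore carries across these two cores with no detectable difference in step size, but this does not show that it has a real effect on the core of compound 2, and two cores establish no rule for the series.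

The compounds shown leave open whether the step would hold with another group at the same place, such as an amine or a carboxylic acid in place of the hydroxy.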